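A Methyl on the Shared Core of Compound 1

This account rests on a few compounds, and the source may have more. Where it says the series, first, only, none or still open, it means among the compounds named here.

Going by the values given here, compound 1 `CC/C=C\C(=O)Nc1cc(Nc2nccc(-c3cn(C)c4ccc(F)cc34)n2)c(OC)cc1N(C)CCN(C)C` is one of two compounds measured in a functional assay on HepG2 cells (Homo sapiens) for antiproliferative activity, read by MTT assay, with a stated time of 72 h (a lower number here means a stronger inhibitor, a higher number a weaker inhibitor), where compound 1 gives 5290 nM. The other is compound 2 `COc1cc(N(C)CCN(C)C)c(NC(=O)/C=C\C(C)C)cc1Nc1nccc(-c2cn(C)c3ccc(F)cc23)n1`, which in this assay gives 3920 nM. The step of a 1.3-fold lower number from compound 1 to compound 2 (0.13 log units; within the scatter) concerns a saturated chain carbon rather than the shared core, and it is within the scatter. Compound 1 stands at one end of these two numbers, but its gap to compound 2 is within the scatter.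

The unmeasured compound 3 `CC/C=C\C(=O)Nc1cc(Nc2nc(C)cc(-c3cn(C)c4ccc(F)cc34)n2)c(OC)cc1N(C)CCN(C)C` differs from compound 1 by methyl in place of hydrogen on an aromatic carbon. Among the compounds with values here, no measured step touches this place on the core; the only step available, a 1.3-fold lower number from compound 1 to compound 2 (0.13 log units; within the scatter), changes a different part of the molecule and is itself within the scatter. With nothing on record for this position, the step of a 1.1-fold lower number from compound 1 to compound 3 (0.02 log units; within the scatter) is expected to be none beyond the scatter. Compound 3 is therefore estimated at 5000 nM, with a range of 2000 nM to 13000 nM.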

Compound 3, half-maximal inhibitory concentration: 11000 nM
Estimate against measurement, compound 3: 2.2-fold (0.34 log units) below, and the stated range covers the measured number.
By their numbers in this assay, from the lowest: compounds 2 and 1 (each within the scatter of the next); then compound 3.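

In this assay, the shared core now has a measured step: methyl in place of hydrogen on the aromatic carbon next to the ring nitrogen gives a 2.1-fold higher number from compound 1 to compound 3 (0.32 log units; beyond the scatter) and so makes a weaker inhibitor. Going by these compounds alone, the only earlier step, on a saturated chain carbon, stayed within the scatter, whereas this methyl, a single heavy atom, moves the number beyond it, though only modestly. Nothing available accounts for this shift at this position.

The compounds shown leave open whether a larger or different group at the same place, such as ethyl or an amine, would raise the number further, leave it unchanged or lower it. They also leave open whether this methyl would produce a step of similar size alongside the side chain of compound 2.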